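The source may hold more compounds than are shown below. What is called first, only, known or untested is meant among the compounds shown, and "the series" means these compounds.

Measured so far:

Compound 1, `N#Cc1cnc(NCc2cnccc2C(F)(F)F)cc1N[C@H]1CC[C@H](O)CC1`, gives 6500 nM in an assay on isolated protein for inhibition of protein kinase C delta type (Homo sapiens), read by TR-FRET, with a stated time of 2 h; a higher number here means a weaker inhibitor, a lower number a stronger inhibitor.
Compound 2, `CO[C@H]1CC[C@@H](Nc2cc(NCc3cnccc3C(F)(F)F)ncc2C#N)CC1`, gives 5000 nM in this assay.
Compound 3, `CC1(C)C[C@H](Nc2cc(NCc3cnccc3C(F)(F)F)ncc2C#N)CC[C@H]1O`, gives 2200 nM in this assay.

All three share the same core and differ only in the saturated ring attached to a nitrogen on an aromatic ring. Compound 3 has the lowest number of the three in this assay: the step is a 2.3-fold lower number from compound 2 to compound 3 (0.36 log units; beyond the scatter), and likewise a 3.0-fold lower number from compound 1 to compound 3 (0.47 log units; beyond the scatter), both beyond the scatter, while compound 1 and compound 2 sit within the scatter of each other, a 1.3-fold lower number from compound 1 to compound 2 (0.11 log units; within the scatter).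

Compound 4, `CC1(C)[C@@H](Nc2cc(NCc3cnccc3C(F)(F)F)ncc2C#N)C[C@@H]1C(N)=O`, has not yet been measured. Its change from compound 3 is 3-carbamoyl-2,2-dimethylcyclobutyl in place of 4-hydroxy-3,3-dimethylcyclohexyl on a nitrogen on an aromatic ring. Among the compounds with values here, none of the measured steps swaps the ring itself; they only vary substituents on the six-membered ring, and those steps were modest. Within the data shown here, the move to a four-membered ring carrying a carboxamide has no direct precedent here, so the expectation is uncertain. Compound 4 is expected to land near compound 3 or somewhat weaker, with the step of a 1.6-fold higher number from compound 3 to compound 4 (0.20 log units; within the scatter) as the estimate. The estimated value for compound 4 in this assay is 3500 nM, within a range of 1000 nM to 12000 nM.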

Compound 4, half-maximal inhibitory concentration: > 10000 nM
Compound 4: no number, only a limit; the forecaster's own chance of this, stated with the estimate: 10%; middle value at least 2.8-fold (0.45 log units) away from the limit.
By their numbers in this assay, from the lowest: compound 3; then compounds 2 and 1 (each within the scatter of the next). At a limit, above all of these: compound 4.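

In this assay compound 4 gives a limit and not a number: the limit of > 10000 nM in this assay, at which 1 of the 4 values shown sits.

Earlier changes at this position only varied substituents on the six-membered ring, and those steps stayed modest. Putting 3-carbamoyl-2,2-dimethylcyclobutyl in place of 4-hydroxy-3,3-dimethylcyclohexyl on the nitrogen, with the heavy-atom, donor and acceptor counts unchanged, gives an at least 4.5-fold higher number from compound 3 to compound 4 (0.65 log units; beyond the scatter), which shows that matching those counts does not keep the number at the level of compound 3. The limit sets compound 4 clearly apart only from compound 3, since the floors of the other two steps lie within the scatter: an at least 2.0-fold higher number from compound 2 to compound 4 (0.30 log units; that floor lies within the scatter) and also an at least 1.5-fold higher number from compound 1 to compound 4 (0.18 log units; that floor lies within the scatter).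

This one change alters the ring size and replaces the hydroxyl with a carboxamide together, so the compounds shown cannot say which of the two accounts for the step. As far as these compounds go, a cyclobutyl ring carrying a hydroxyl and a cyclohexyl ring carrying a carboxamide would pull the two apart, and how far compound 4 really lies beyond its limit also remains open.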